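Acetyl in Place of Ethyl on a Ring Nitrogen

A few compounds are considered here, and "the series" means these few. Any claim that something is new, unique, unknown or untested is made for them only; others in the source may bear on it.

Compound 1 `CCN1CCN(CC(=O)N(Cc2ccc(OC)cc2)c2cc(OC)c(OC)c(OC)c2)CC1`: in a functional assay on HCT-116 cells (Homo sapiens) for inhibition, read by CCK-8 assay, with a stated time of 48 h (a lower number here means a stronger inhibitor, a higher number a weaker inhibitor), compound 1 gives > 20000 nM, which is a limit of the assay and not a number.
Compound 2 `COc1ccc(CN(C(=O)CN2CCN(C(C)=O)CC2)c2cc(OC)c(OC)c(OC)c2)cc1`: in this assay compound 2 gives > 20000 nM, likewise a limit.
Compound 3 `CCN1CCN(C(=S)SCC(=O)N(Cc2ccc(OC)c(O)c2)c2cc(OC)c(OC)c(OC)c2)CC1`: in this assay compound 3 gives 530 nM.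

Compound 2 differs from compound 1 by acetyl in place of ethyl on an amine nitrogen in a ring. The step that the two limits leave unreadable from compound 1 to compound 2 cannot be sized, since both values sit at the limit of > 20000 nM in this assay, at which 2 of the 3 values shown sit. The core of compound 3 differs from that of compound 1, but the difference between the two cores is not broken down here. Compound 4 `COc1ccc(CN(C(=O)CSC(=S)N2CCN(C(C)=O)CC2)c2cc(OC)c(OC)c(OC)c2)cc1O`, not yet measured, differs from compound 3 by acetyl in place of ethyl on an amine nitrogen in a ring, the same change at the same place. Among the compounds with values here, no measured step tells how large this change is, so compound 4 is expected to land near compound 3, with wide uncertainty. For compound 4 an estimate of 1200 nM is given, spanning 250 nM to 8000 nM, which means an expected step of a 2.3-fold higher number from compound 3 to compound 4 (0.35 log units; beyond the scatter).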

Compound 4, half-maximal inhibitory concentration: 780 nM
Beside the measured number, compound 4's estimate is 1.5-fold (0.19 log units) above it; the measured number falls inside the stated range.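

In this assay, acetyl in place of ethyl on the ring nitrogen of the core of compound 3 gives a 1.5-fold higher number from compound 3 to compound 4 (0.17 log units; within the scatter). The same change on the core of compound 1 cannot be read, so there is no size to set beside the new step: the limit of > 20000 nM in this assay, at which 2 of the 4 values shown sit. The series thus offers one readable instance of this change, which does not show that it carries from one core to the other with the same size.

On these data alone, it remains open how a longer alkyl chain, a primary amine or a carboxylic acid in place of ethyl on that ring nitrogen would read in this assay. Also open, as far as these compounds go, is how the acetyl change reads on any further core where neither partner sits at a limit.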